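Swapping a Pyridyl for a Methoxyphenyl on the Triazole

The source may hold more compounds than are shown below. What is called first, only, known or untested is meant among the compounds shown, and "the series" means these compounds.

Measured so far:
- Compound 1 `C=C1C(=O)[C@]23C[C@@]1(O)CC[C@H]2c1ccc(OS(=O)(=O)c2ccc(C)cc2)c(C)c1[C@@H]3Cn1cc(-c2ccccn2)nn1`: 1970 nM
- Compound 2 `C=C1C(=O)[C@]23C[C@@]1(O)CC[C@H]2c1ccc(O)c(C)c1[C@@H]3Cn1cc(-c2ccccn2)nn1`: 410 nM
- Compound 3 `C=C1C[C@]23C[C@@]1(O)CC[C@@H]2c1cccc(C)c1[C@@H]3Cn1cc(-c2ccccc2)nn1`: > 20000 nM

Among the compounds with values here, in a functional assay on SW480 cells (Homo sapiens) for cytotoxicity, read by MTT assay, with a stated time of 4 days (on this read-out higher numbers stand for weaker inhibition and lower numbers for stronger inhibition), compound 1 sits at the higher of the two numbers known, and compound 2 sits some way beneath it. The step of a 4.8-fold lower number from compound 1 to compound 2 (0.68 log units; beyond the scatter) shows that removing the sulfonyl ester from the phenol oxygen on the shared core lowers the number well beyond the usual scatter. For compound 3 this assay gives only a limit, > 20000 nM, and that is all its value can say (the limit of > 20000 nM in this assay, at which 1 of the 3 values shown sits).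

Compound 4 `C=C1C(=O)[C@]23C[C@@]1(O)CC[C@H]2c1ccc(OS(=O)(=O)c2ccc(C)cc2)c(C)c1[C@@H]3Cn1cc(-c2ccc(OC)cc2)nn1` keeps the sulfonyl ester of compound 1 and changes only the group on the triazole: 4-methoxyphenyl in place of pyridin-2-yl on an aromatic carbon. Within the data shown here, no measured pair differs in exactly this place, so the only direct step known, a 4.8-fold lower number from compound 1 to compound 2 (0.68 log units; beyond the scatter), touches a different part of the molecule. Compound 3 carries a plain phenyl on its triazole, but it also differs from compound 1 in its core, so its limit cannot be read as a step.

Compound 4 is therefore expected to stay close to compound 1, with the estimated step of a 1.5-fold higher number from compound 1 to compound 4 (0.18 log units; within the scatter) leaning slightly toward a higher number. The estimate for compound 4 is 3000 nM, within a range from 1000 nM to 12000 nM.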

Compound 4, half-maximal inhibitory concentration: 1640 nM
The estimate for compound 4 lay 1.8-fold (0.26 log units) above the measured number; the measured number falls inside the stated range.
By their numbers in this assay, from the lowest: compound 2; then compounds 4 and 1 (each within the scatter of the next). At a limit, above all of these: compound 3.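

In this assay, putting 4-methoxyphenyl in place of pyridin-2-yl on the triazole gives a 1.2-fold lower number from compound 1 to compound 4 (0.08 log units; within the scatter). Within the data shown here, this is the first measured pair that differs at this position, and it shows that, with the sulfonyl ester kept on the phenol oxygen, a ring of carbon only bearing a methoxy group and a ring holding a nitrogen cannot be told apart in this read-out, even though the entering group is the larger of the two. Among these compounds, nothing measured so far accounts for this likeness between the two groups.

The compounds shown leave open whether 4-methoxyphenyl would read the same way on the free phenol of compound 2, which gives 410 nM, as the present pair speaks only for the sulfonyl ester series. Also open, as far as these compounds go, is what a group of a different kind would do at this place on the triazole, such as a pyridine bearing an amine, a phenyl ring bearing a carboxylic acid, or a longer alkyl chain in place of the aromatic ring.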